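Fluoro to chloro on compound 2

A few compounds are considered here, and "the series" means these few. Any claim that something is new, unique, unknown or untested is made for them only; others in the source may bear on it.

In a functional assay on HeLa cells (Homo sapiens) for antiproliferative activity, read by MTT assay, with a stated time of 48 h (a higher number here means a weaker inhibitor, a lower number a stronger inhibitor), compound 1 `Fc1ccc(-c2nn(-c3ccccc3)cc2-c2nc3ccccc3[nH]2)cc1` gives 2330 nM, compound 2 `Fc1ccc(-c2nn(-c3ccccc3)cc2-c2nc3cc(F)ccc3[nH]2)cc1` gives 1570 nM, and compound 3 `Cc1ccc2[nH]c(-c3cn(-c4ccccc4)nc3-c3ccc(F)cc3)nc2c1` gives 3630 nM. Compound 2 sits at the low end of these numbers, but the data show a 1.5-fold lower number from compound 1 to compound 2 (0.17 log units; within the scatter), which leaves it level with its unsubstituted neighbour. Only a 2.3-fold higher number from compound 2 to compound 3 (0.36 log units; beyond the scatter) sets it apart, while a 1.6-fold higher number from compound 1 to compound 3 (0.19 log units; within the scatter) again stays small.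

Compound 4 `Fc1ccc2[nH]c(-c3cn(-c4ccccc4)nc3-c3ccc(Cl)cc3)nc2c1` differs from compound 2 at one place: chloro in place of fluoro on an aromatic carbon. This is chloro in place of fluoro on an aromatic carbon, para to a large group, turning 4-fluorophenyl to 4-chlorophenyl. Going by the values given here, none of the measured steps touches this place, and none brings in chloro, so they offer only indirect guidance. They show that single swaps elsewhere in the shared core move the number little, the largest being a 2.3-fold higher number from compound 2 to compound 3 (0.36 log units; beyond the scatter). No step beyond the scatter is therefore expected, and the estimated change is a 1.1-fold lower number from compound 2 to compound 4 (0.05 log units; within the scatter). The expected value for compound 4 is 1400 nM, with an estimated range from 650 nM to 3000 nM.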

Compound 4, half-maximal inhibitory concentration: 2770 nM
Compound 4: the middle estimate sits 2.0-fold (0.30 log units) below what was measured; low and high end bracket the measured number.
By their numbers in this assay, from the lowest: compounds 2, 1, 4 and 3 (each within the scatter of the next, the first and the last beyond it).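

Going by these compounds alone, the first swap at this place, 4-fluorophenyl to 4-chlorophenyl, gives in this assay a 1.8-fold higher number from compound 2 to compound 4 (0.25 log units; within the scatter) and so stays within the scatter. Within the data shown here, at this position, para to a large group on the shared core, the two halogens therefore cannot be told apart on these numbers, and the single step gives no sign that the position responds to this change. Nothing in the data offers an explanation of this result.

The compounds shown carry only fluoro and chloro at this place, so it stays open what an amine, a carboxylic acid or a methoxy group would do there. From the compounds shown here alone, it also stays open whether chloro would read the same on the cores of compound 1 and compound 3, as this one step rests on the core of compound 2 alone.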